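Swapping One Stereocentre in a Lactone Cytotoxin

A few compounds are considered here, and "the series" means these few. Any claim that something is new, unique, unknown or untested is made for them only; others in the source may bear on it.

Compound 2 `CCCCC[C@H](CCC[C@@H]1CC=CC(=O)O1)OC` is one of three closely related compounds tested in a functional assay on A2780 ADR cells (Homo sapiens) for cytotoxicity, read by MTT assay, with a stated time of 24 h; on this read-out lower numbers stand for stronger inhibition and higher numbers for weaker inhibition. Compound 2 gives 20500 nM. Its mirror image, compound 1 `CCCCC[C@@H](CCC[C@H]1CC=CC(=O)O1)OC`, gives 9000 nM in this assay, and compound 3 `CCCCC[C@H](C[C@H](O)C[C@@H]1CC=CC(=O)O1)OC`, which carries an additional hydroxy group on the chain, gives 30000 nM. On these numbers compound 2 stands second highest of the three: the step of a 2.3-fold higher number from compound 1 to compound 2 (0.36 log units; beyond the scatter), while the step of a 1.5-fold higher number from compound 2 to compound 3 (0.17 log units; within the scatter).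

Compound 4 `CCCCC[C@@H](CCC[C@@H]1CC=CC(=O)O1)OC` has not yet been measured. Compared with compound 2, (the two compounds have the same atoms and bonds and differ only in configuration as drawn: 1 of 2 stereo elements differ; a stereocentre at a saturated chain carbon is drawn R in compound 2 and S in compound 4). Going by the values given here, only one measured step bears on a change of configuration, namely a 2.3-fold higher number from compound 1 to compound 2 (0.36 log units; beyond the scatter), which inverted both stereocentres at once and rests on nothing more than the fact that compounds 1 and 2 differ only in the configuration as drawn. Compound 4 keeps the ring configuration of compound 2 and takes the chain configuration of compound 1, so it is a hybrid of the two measured mirror images. A step smaller than the one between the mirror images is therefore expected, toward a lower number, and the step of a 1.5-fold lower number from compound 2 to compound 4 (0.17 log units; within the scatter) is the estimate. For compound 4 the expected value in this assay is 14000 nM, with a range from 5000 nM to 40000 nM.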

Compound 4, half-maximal inhibitory concentration: 11500 nM
The estimate for compound 4 lay 1.2-fold (0.09 log units) above the measured number; the measured number falls inside the stated range.
By their numbers in this assay, from the lowest: compounds 1, 4, 2 and 3 (each within the scatter of the next, the first and the last beyond it).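

Compound 4 separates the two stereocentres that the mirror-image pair changed together. In this assay the saturated chain carbon inverted alone gives a 1.8-fold lower number from compound 2 to compound 4 (0.25 log units; within the scatter) and the saturated ring carbon inverted alone gives a 1.3-fold higher number from compound 1 to compound 4 (0.11 log units; within the scatter), so neither single inversion can be read as a real change, while only the inversion of both at once stands clear of the scatter (a 2.3-fold higher number from compound 1 to compound 2 (0.36 log units; beyond the scatter)). Any gap among these three compounds can come from configuration alone, because no atom or bond differs between them: the fact that compounds 2 and 4 differ only in the configuration as drawn.

The compounds shown leave open how the remaining combination would read, with the chain carbon drawn R and the ring carbon drawn S, and so whether the two stereocentres act independently. They also leave open whether the chain tolerates more than a change of configuration, for instance an amine on that chain carbon or a longer chain, since only the inversions and one added hydroxy group are shown here.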